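Ring swap on the side chain of compound 2

The source may report more compounds than this note shows. Statements on the series, on what has been measured and on what is new or still open speak of the compounds shown alone.

Among the measured compounds shown here, in a functional assay on A549 cells (Homo sapiens) for cytotoxicity, read by MTT assay, with a stated time of 72 h (on this read-out higher numbers stand for weaker inhibition and lower numbers for stronger inhibition), compound 2 `CN1CCN(CCCCn2c3c(c4ccccc42)C(=O)c2c[n+]([O-])c4ccccc4c2C3=O)CC1` gives 90 nM, the lowest of the three numbers so far. Compound 1 `O=C1c2c[n+]([O-])c3ccccc3c2C(=O)c2c1c1ccccc1n2Cc1cn(CC(O)CO)nn1` gives 880 nM and compound 3 `CC1(C)OC[C@@H](Cn2cc(Cn3c4c(c5ccccc53)C(=O)c3c[n+]([O-])c5ccccc5c3C4=O)nn2)O1` gives 4700 nM. The next compound, compound 4 `O=C1c2c[n+]([O-])c3ccccc3c2C(=O)c2c1c1ccccc1n2CCCCN1CCCCC1`, differs from compound 2 by piperidin-1-yl in place of 4-methylpiperazin-1-yl on a saturated chain carbon, four bonds along the chain from an aromatic nitrogen. This places piperidin-1-yl in place of 4-methylpiperazin-1-yl on a saturated chain carbon, four bonds along the chain from an aromatic nitrogen.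

For the measured compounds named here, two measured steps bear on this only indirectly. Exchange of the whole side chain gave a 9.8-fold lower number from compound 1 to compound 2 (0.99 log units; beyond the scatter), and protection of the diol gave a 5.3-fold higher number from compound 1 to compound 3 (0.73 log units; beyond the scatter). Both lie beyond the scatter, so changes in this region of the series can register in this assay. Going by the values given here, neither step swaps one of these rings for the other, so no direct precedent exists. The butyl-length chain and a six-membered non-aromatic ring remain in place, so the estimated change is small, a 1.2-fold higher number from compound 2 to compound 4 (0.09 log units; within the scatter), and is not expected to exceed the scatter. For compound 4, the expected value is 110 nM, with an estimated range of 35 nM to 350 nM.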

Compound 4, half-maximal inhibitory concentration: 150 nM
The estimate for compound 4 lay 1.4-fold (0.13 log units) below the measured number; the range from low to high includes it.
By their numbers in this assay, from the lowest: compounds 2 and 4 (each within the scatter of the next); then compound 1; then compound 3.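

Piperidin-1-yl in place of 4-methylpiperazin-1-yl, on a saturated chain carbon four bonds along the chain from an aromatic nitrogen, gives a 1.7-fold higher number from compound 2 to compound 4 (0.22 log units; within the scatter) in this assay and so the two rings are not separated at this position. The methyl-bearing second ring nitrogen of compound 2 is therefore not needed for a number in this range, and the gain over the triazole diol side chain remains without it, with a 5.9-fold lower number from compound 1 to compound 4 (0.77 log units; beyond the scatter) still beyond the scatter. Nothing measured here accounts for either step.

Open, from the compounds shown here alone, is whether a ring is needed at all at the chain end, which an open-chain dimethylamino group on the same chain would address. Also open, going by these compounds, are morpholin-4-yl as the ring and a longer chain carrying piperidin-1-yl.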